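From nitrile chain to chlorophenyl on the amide nitrogen

The source may hold more compounds than are shown below. What is called first, only, known or untested is meant among the compounds shown, and "the series" means these compounds.

Compound 1, `Cc1c(C(C)C)c(=O)on1C(=O)N(C)Cc1cccs1` — in an assay (strain Wistar) for inhibition of Hormone-sensitive lipase (Rattus norvegicus), read by spectrophotometry (on this read-out lower numbers stand for stronger inhibition and higher numbers for weaker inhibition), compound 1 gives 2 nM.
Compound 2, `Cc1c(C(C)C)c(=O)on1C(=O)N(C)CCC#N` — in this assay compound 2 gives > 1000 nM.

The value for compound 2 is a limit of the assay, not a number; compound 2 sits at the limit of > 1000 nM in this assay, at which 1 of the 2 values shown sits. It therefore stands, as far as the numbers show, at the weak end of the pair, and the step of an at least 500-fold higher number from compound 1 to compound 2 (2.69 log units; beyond the scatter) only sets a floor on how far it fell from compound 1.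

Compound 3, `Cc1c(C(C)C)c(=O)on1C(=O)N(C)c1ccc(Cl)cc1`, is the next step from compound 2: 4-chlorophenyl in place of 2-cyanoethyl on an amide-type nitrogen. For the measured compounds named here, the one measured step that bears on this position is an at least 500-fold higher number from compound 1 to compound 2 (2.69 log units; beyond the scatter), where an aromatic ring on the chain carbon bound to the amide-type nitrogen gave the strong value and the nitrile chain the limit. Returning an aromatic ring, now directly on the nitrogen, is expected to recover much of that loss, so a large step downward in this assay is expected, though the limit on compound 2 leaves its true size open. Compound 3 is estimated at 15 nM, within 2 nM to 300 nM, which means an expected step of an at least 66-fold lower number from compound 2 to compound 3 (1.82 log units; beyond the scatter).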

Compound 3, half-maximal inhibitory concentration: 17 nM
Beside the measured number, compound 3's estimate is 1.1-fold (0.05 log units) below it, and the stated range covers the measured number.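

An aromatic ring bound directly to the amide-type nitrogen, with no saturated chain carbon, brings back strong inhibition in this assay, with an at least 58-fold lower number from compound 2 to compound 3 (1.76 log units; beyond the scatter). The size of that step is only a floor, and the value it starts from is a limit of the assay and not a number: the limit of > 1000 nM in this assay, at which 1 of the 3 values shown sits.

Set against the (thiophen-2-yl)methyl group, the 4-chlorophenyl group gives an 8.5-fold higher number from compound 1 to compound 3 (0.93 log units; beyond the scatter), so the directly bound ring is strong but does not match the earlier group, and since the ring, the chlorine and the chain carbon all change in this one step, it cannot show which of them accounts for the difference.

Going by these compounds, it remains open whether the chlorine contributes at all, which a plain phenyl group on the same nitrogen would address, and whether a 4-chlorobenzyl group would separate the effect of the chain carbon from that of the ring. On these data alone, it is also open whether an aromatic ring is needed here, or whether a cyclohexyl group or a longer saturated chain would serve as well.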